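A few compounds are considered here, and "the series" means these few. Any claim that something is new, unique, unknown or untested is made for them only; others in the source may bear on it.

Series notes, continued. Going by the values given here, compound 2 `CCCCNC(=O)CCC1CCN(c2nc(N)c3cc(OC)c(OC)cc3n2)CC1` gives 0.47 nM in an assay on isolated protein for displacement of a labelled ligand from Adrenergic receptor alpha-1 (Rattus norvegicus) (a higher number here means a weaker inhibitor, a lower number a stronger inhibitor), the lowest of the two numbers so far; compound 1 `COc1cc2nc(N3CCC(CC(=O)NCC4CC4)CC3)nc(N)c2cc1OC` gives 1.08 nM, and the step of a 2.3-fold lower number from compound 1 to compound 2 (0.36 log units; beyond the scatter) touched only the amide end of the side chain. Compound 3 `CCCCNC(=O)COC1CCN(c2nc(N)c3cc(OC)c(OC)cc3n2)CC1` carries (butylcarbamoyl)methoxy in place of 2-(butylcarbamoyl)ethyl on a saturated ring carbon. Among the compounds with values here, no measured step bears on a change of this kind: the linker between the ring carbon and the butylcarbamoyl group has not been varied. Expectation for compound 3 is therefore a step of a 1.3-fold higher number from compound 2 to compound 3 (0.11 log units; within the scatter), not beyond the scatter, with an estimated 0.6 nM in this assay, range 0.2 nM to 2 nM.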

Compound 3, inhibition constant: 0.79 nM
Estimate against measurement, compound 3: 1.3-fold (0.12 log units) below; the measured number falls inside the stated range.
By their numbers in this assay, from the lowest: compounds 2, 3 and 1 (each within the scatter of the next, the first and the last beyond it).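

In this assay, going by these compounds alone, the first change to the linker at this saturated ring carbon, (butylcarbamoyl)methoxy in place of 2-(butylcarbamoyl)ethyl, gives a 1.7-fold higher number from compound 2 to compound 3 (0.23 log units; within the scatter), so this position tolerates the exchange without a step beyond the scatter. (Butylcarbamoyl)methoxy in place of ((cyclopropylmethyl)carbamoyl)methyl gives a 1.4-fold lower number from compound 1 to compound 3 (0.14 log units; within the scatter), so compound 3 cannot be separated from either compound 1 or compound 2, although those two stand apart. No evidence is available that bears on this result.

As far as these compounds go, whether an amine in the linker, or a longer chain there, would hold the number in the same range remains open.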